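A few compounds are considered here, and "the series" means these few. Any claim that something is new, unique, unknown or untested is made for them only; others in the source may bear on it.

Measured compounds:
- Compound 1 `Cc1cc(C)c(Oc2cc(Nc3ccc(C#N)cc3)ncc2C(=O)NCc2cn(Cc3cccc(Cl)c3)nn2)c(C)c1`: 187000 nM
- Compound 2 `Cc1cc(C)c(Oc2cc(Nc3ccc(C#N)cc3)ncc2C(=O)NCc2cn(CC(=O)N3CCOCC3)nn2)c(C)c1`: 181000 nM
- Compound 3 `Cc1cc(C)c(Oc2cc(Nc3ccc(C#N)cc3)ncc2C(=O)NCc2cn(Cc3ccc(Cl)cc3)nn2)c(C)c1`: >= 120000 nM

All three share one core and were tested in an ADME assay on MT4 cells (Homo sapiens) for cytotoxicity, read by MTT assay, with a stated time of 5 days; on this read-out higher numbers stand for lower toxicity in this test and lower numbers for higher toxicity in this test. Compound 1 gives 187000 nM and compound 2 gives 181000 nM; the two sit within the scatter of each other, as the step of a 1.0-fold lower number from compound 1 to compound 2 (0.01 log units; within the scatter) shows. For compound 3 the assay reports only a limit, >= 120000 nM; it is the limit (the limit of >= 120000 nM in this assay, at which 1 of the 3 values shown sits), not a number. So compound 3 stands at the edge of what the assay can read, while compound 1 and compound 2 have readable values.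

Compound 4 `Cc1cc(C)c(Oc2cc(Nc3ccc(C#N)cc3)ncc2C(=O)NCc2cn(Cc3ccccc3C)nn2)c(C)c1` has not been measured. It differs from compound 3 in one place: 2-methylphenyl in place of 4-chlorophenyl on a saturated chain carbon bound to an aromatic nitrogen. Two measured steps lead into compound 3, a step that the limit leaves unreadable from compound 1 to compound 3 and a step that the limit leaves unreadable from compound 2 to compound 3, and neither can be sized. For the measured compounds named here, the one readable step, a 1.0-fold lower number from compound 1 to compound 2 (0.01 log units; within the scatter), swaps a different pair of groups and is within the scatter. Nothing measured here separates a 2-methylphenyl from a 4-chlorophenyl at this position, so no step beyond the scatter is expected; the estimated step is a step that the limit leaves unreadable from compound 3 to compound 4. Compound 4 is therefore expected at about 150000 nM, with a range from 70000 nM to 250000 nM.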

Compound 4, half-maximal cytotoxic concentration: >= 164000 nM
Compound 4: only a limit was reported; the forecaster's own chance of this, stated with the estimate: 50%; middle value at least 1.0-fold (0.03 log units) away from the limit.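

In this assay compound 4 is reported only as a limit (>= 164000 nM), not a number. Compound 3 also has only a limit, so the steps to compound 4 from compound 1, compound 2 and compound 3 cannot be read. The compounds shown leave open how far 2-methylphenyl and 4-chlorophenyl differ at this place, if at all.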